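The compounds below may be only part of what the source reports. "The series", "measured", "known", "first", "only" and "open" are said of these compounds alone.

Measured compounds:
compound 1 `CCCC(=O)N1CCC(NS(=O)(=O)c2ccc(NC(=O)C(CC)CC)c3ccccc23)CC1` – in an in vitro functional assay on CHO/Galpha16 cells for antagonist activity at C-C chemokine receptor type 8 (Homo sapiens), read by FLIPR (on this read-out lower numbers stand for stronger inhibition and higher numbers for weaker inhibition), compound 1 gives 639 nM
compound 2 `CCCCc1ccc(C(=O)Nc2ccc(S(=O)(=O)NC3CCN(C(=O)CCC)CC3)c3ccccc23)cc1` – in this assay compound 2 gives 15.3 nM
compound 3 `CCCC(=O)N1CCC(NS(=O)(=O)c2ccc(NC(=O)c3ccccn3)c3ccccc23)CC1` – in this assay compound 3 gives 41.7 nM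

Among these three, compound 3 stands second: it lies nearer to compound 2, from which it is separated by a step of a 2.7-fold higher number from compound 2 to compound 3 (0.44 log units; beyond the scatter), than to compound 1, from which it is separated by a 15-fold lower number from compound 1 to compound 3 (1.19 log units; beyond the scatter).

Compound 4 `CCCC(=O)N1CCC(NS(=O)(=O)c2ccc(NC(=O)C3CCCC3)c3ccccc23)CC1` is the next member of the series. It differs from compound 3 in one place: cyclopentyl in place of pyridin-2-yl on a carbonyl carbon.

Within the data shown here, two measured steps bear on this change, both passing through the same carbonyl carbon. Replacing pentan-3-yl by pyridin-2-yl gave a 15-fold lower number from compound 1 to compound 3 (1.19 log units; beyond the scatter), and replacing 4-butylphenyl by pyridin-2-yl gave a 2.7-fold higher number from compound 2 to compound 3 (0.44 log units; beyond the scatter). The cyclopentyl group that enters compound 4 has no aromatic ring and no hydrogen-bond acceptor, which places it closer to the pentan-3-yl of compound 1 than to the groups of compound 2 or compound 3. The step from compound 3 to compound 4 is therefore expected to run toward a higher number in this assay, though not necessarily the whole way back to compound 1, so compound 4 is estimated at 300 nM (range 80 nM to 1200 nM), corresponding to an expected step of a 7.2-fold higher number from compound 3 to compound 4 (0.86 log units; beyond the scatter).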

Compound 4, half-maximal inhibitory concentration: 365 nM
Beside the measured number, compound 4's estimate is 1.2-fold (0.09 log units) below it; measured number inside the range.
By their numbers in this assay, from the lowest: compound 2; then compound 3; then compounds 4 and 1 (each within the scatter of the next).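

The cyclopentyl group separates having a ring on this carbonyl carbon from having an aromatic one: in this assay the exchange for pyridin-2-yl gives an 8.8-fold higher number from compound 3 to compound 4 (0.94 log units; beyond the scatter), and the exchange for 4-butylphenyl gives a 24-fold higher number from compound 2 to compound 4 (1.38 log units; beyond the scatter). The ring closure alone therefore brings no measurable gain over the open pentan-3-yl group, since the step from that group is a 1.8-fold lower number from compound 1 to compound 4 (0.24 log units; within the scatter), which leaves the two non-aromatic groups indistinguishable in this read-out. Across these four compounds, the two with an aromatic ring on the carbonyl carbon, compound 2 and compound 3, give lower numbers than the two without one, compound 1 and compound 4, and no compound shown goes against this.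

The compounds shown leave open whether the aromatic ring itself carries this difference, which an unsubstituted phenyl, a pyridin-3-yl or a piperidin-4-yl on the same carbonyl carbon could help to settle, and how much of the low number of compound 2 belongs to its butyl chain. Nothing presented here explains why these groups differ.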